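The source may hold more compounds than are shown below. What is called first, only, known or untested is meant among the compounds shown, and "the series" means these compounds.

In an ADME assay on cells (Hepatocyte, Mus musculus) for cytotoxicity, read by MTT assay, with a stated time of 24 h (a lower number here means that less compound is tolerated, a higher number that more compound is tolerated), the measured compounds read as follows:

compound 1 `COc1ccc(S(=O)(=O)n2c(-c3cn(-c4ccccc4)nc3-c3ccc(F)cc3)nc3ccccc32)cc1` gives 105000 nM
compound 2 `O=S(=O)(c1ccccc1)n1c(-c2cn(-c3ccccc3)nc2-c2ccc(C(F)(F)F)cc2)nc2ccccc21` gives 186000 nM

Compound 2, at 186000 nM on this scale, lies within the usual scatter of compound 1, and no order between the two can be read. The step under consideration leads to compound 3 `COc1ccc(S(=O)(=O)n2c(-c3cn(-c4ccccc4)nc3-c3ccc(C(F)(F)F)cc3)nc3ccccc32)cc1` in which the phenylsulfonyl group of compound 2 becomes (4-methoxyphenyl)sulfonyl. The change is methoxy in place of hydrogen on an aromatic carbon with the methoxy group on an aromatic carbon of a six-membered aromatic ring of carbon only, para to a large group.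

For the measured compounds named here, no measured pair isolates this change, so this assay offers no direct step to go by. Compound 1 also carries the (4-methoxyphenyl)sulfonyl group and gives 105000 nM within the scatter of compound 2, so no step beyond the scatter is expected in either direction. The expected change is a 1.2-fold lower number from compound 2 to compound 3 (0.09 log units; within the scatter) and it stays within the scatter. Compound 3 is estimated at 150000 nM with an expected range from 75000 nM to 300000 nM in this assay ahead of any measurement.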

Compound 3, half-maximal cytotoxic concentration: 87400 nM
For compound 3 the middle estimate is 1.7-fold (0.23 log units) above the measured one; measured number inside the range.
By their numbers in this assay, from the lowest: compounds 3, 1 and 2 (each within the scatter of the next, the first and the last beyond it).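

In this assay, for the compounds shown here, methoxy in place of hydrogen, on an aromatic carbon para to a large group, gives the first reading at this position: the series shows a 2.1-fold lower number from compound 2 to compound 3 (0.33 log units; beyond the scatter) as a modest step, with the trifluoromethyl group held constant. Trifluoromethyl in place of fluoro, with the (4-methoxyphenyl)sulfonyl group common to both compounds, reads as a 1.2-fold lower number from compound 1 to compound 3 (0.08 log units; within the scatter) and gives no order between that pair, so in this small set only the sulfonyl-side change moves the number beyond the scatter. Nothing independent of this read-out bears on the result, and the modest methoxy step stands as an observation only.

Whether the methoxy step carries over to a compound with fluoro in place of trifluoromethyl remains open, as the compounds shown hold a single pair that isolates this change. Also open, going by these compounds, is how an amine, a hydroxy group or a longer alkoxy chain such as ethoxy would read at the same position, and whether any of these would move the number in the same direction as methoxy.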